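Isopropoxy to ethoxy: compound 2 toward compound 4

This account rests on a few compounds, and the source may have more. Where it says the series, first, only, none or still open, it means among the compounds named here.

Three compounds in this series have numbers in a functional assay on aorta (Rattus norvegicus, strain Wistar) for inhibition, with a stated time of 60 min; a higher number here means a larger maximal response, a lower number a smaller maximal response. Compound 1 `O=[N+]([O-])c1ccccc1-c1nc2cc(C(F)(F)F)ccc2[nH]1` gives 85.3%, compound 3 `COc1cc(-c2nc3cc(C(F)(F)F)ccc3[nH]2)ccc1O` gives 97.7%, and compound 2 `CC(C)Oc1ccccc1-c1nc2cc([N+](=O)[O-])ccc2[nH]1` gives 31.7%, the lowest of the three. Compound 1 stands nearest to compound 2, its value higher by a margin beyond the scatter, and compound 3 stands furthest, also higher beyond the scatter. Within the data shown here, no two measured compounds differ in one place only, so no single-point step is available for calibration. Compound 4 `CCOc1ccccc1-c1nc2cc([N+](=O)[O-])ccc2[nH]1` differs from compound 2 by hydrogen in place of methyl on a saturated chain carbon bound to an oxygen on an aromatic ring and a saturated chain carbon. The expected step in this assay, a number 8.3 percentage points higher from compound 2 to compound 4 (within the scatter), is small and upward if anything, possibly within the scatter. Compound 4 is estimated at 40%, with a range from 20% to 65%.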

Compound 4, largest response reached (Emax), in percent of the reference or control that the assay uses: 46.4%
Compound 4: the middle estimate sits 6.4 percentage points below what was measured, within the range that was stated.
By their numbers in this assay, from the lowest: compound 2; then compound 4; then compound 1; then compound 3.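

Isopropoxy to ethoxy gives the first one-place step in this series: in this assay the change reads a number 14.7 percentage points higher from compound 2 to compound 4 (beyond the scatter). Hydrogen in place of methyl on this saturated chain carbon thus moves the maximal response beyond the scatter, so the branching methyl on this chain is not a silent change here. No measurement among these compounds accounts for the step.

On these data alone, whether methoxy or a longer chain such as n-butoxy would continue this direction remains open. Also open, as far as these compounds go, is whether the same change would hold with trifluoromethyl on the core in place of nitro.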